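This account rests on a few compounds, and the source may have more. Where it says the series, first, only, none or still open, it means among the compounds named here.

Of the compounds shown here, three have been measured in a functional assay on MCF7 cells (Homo sapiens) for inhibition, read by MTT assay, with a stated time of 48 h; on this read-out higher numbers stand for weaker inhibition and lower numbers for stronger inhibition. Compound 1 `O=C(C=CNc1cc(-c2ccccc2)nn1-c1ccccc1)c1ccc(F)cc1` gives 9180 nM, compound 3 `COc1ccc(C(=O)C=CNc2cc(-c3ccccc3)nn2-c2ccccc2)cc1` gives 1290 nM, and compound 2 `Cc1ccc(-c2ccnc3c2c(-c2ccccc2)nn3-c2ccccc2)cc1` gives 5590 nM, which is the second highest of the three numbers; its gap to compound 1 is within the scatter, while compound 3 gives a number a 7.1-fold lower number from compound 1 to compound 3 (0.85 log units; beyond the scatter) than compound 1.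

Compound 4 `COc1ccc(-c2ccnc3c2c(-c2ccccc2)nn3-c2ccccc2)cc1` differs from compound 2 in one place: methoxy in place of methyl on an aromatic carbon. Among the measured compounds shown here, the only measured step that touches methoxy is the one from compound 1 to compound 3, but there the group replaced was fluoro, on a different shared core, so it bears on this step only loosely. A modest lowering is therefore expected, a 1.6-fold lower number from compound 2 to compound 4 (0.20 log units; within the scatter). In this assay compound 4 is expected to give about 3500 nM, somewhere between 1400 nM and 9000 nM.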

Compound 4, half-maximal inhibitory concentration: 28700 nM
Compound 4: the middle estimate sits 8.2-fold (0.91 log units) below what was measured; the measured number lies above the stated range.
By their numbers in this assay, from the lowest: compound 3; then compounds 2 and 1 (each within the scatter of the next); then compound 4.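

In this assay, changing 4-methylphenyl to 4-methoxyphenyl brings a 5.1-fold higher number from compound 2 to compound 4 (0.71 log units; beyond the scatter), so inhibition on this core weakens clearly. Methoxy therefore does not lower the number in every setting: a 7.1-fold lower number from compound 1 to compound 3 (0.85 log units; beyond the scatter) went the other way, but that step replaced fluoro on a different core, so the two steps cannot separate the role of the core from that of the group replaced. Nothing measured here gives a reason for the rise.

Still open, going by these compounds, is how fluoro would read at this place on this core. An amine or a carboxylic acid there is also untested among the compounds shown.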